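Trimming a methoxy group in a pyrazole chalcone series

The compounds below may be only part of what the source reports. "The series", "measured", "known", "first", "only" and "open" are said of these compounds alone.

Of the compounds shown here, three of a shared core have been measured so far. In a functional assay on NCI-H522 cells (Homo sapiens) for cytotoxicity, read by sulforhodamine B assay, with a stated time of 48 h, tested at 0.1 uM (a lower number here means a stronger effect, a higher number a weaker effect of the compound at the concentration tested), compound 2 `COc1cc(-c2cc(/C=C/C(=O)c3ccc(N)cc3)[nH]n2)cc(OC)c1OC` gives 92%, the second highest of the three numbers; compound 1 `COc1ccc(-c2cc(/C=C/C(=O)c3ccc(N)cc3)[nH]n2)cc1` gives 85%, and compound 3 `COc1cc(-c2cc(/C=C/C(=O)c3ccc(F)c(F)c3)[nH]n2)cc(OC)c1OC` gives 99%. Going by the values given here, the one step between compounds that differ in a single place, a number 7 percentage points higher from compound 2 to compound 3 (within the scatter), was within the scatter. Compound 4 `COc1ccc(-c2cc(/C=C/C(=O)c3ccc(N)cc3)[nH]n2)cc1OC` differs from compound 2 by hydrogen in place of methoxy on an aromatic carbon. Among the compounds with values here, no measured step removes a methoxy group, and the values of compound 1 and compound 2 lie within the scatter of each other. Compound 4 is therefore expected to show no step beyond the scatter, a number 3 percentage points lower from compound 2 to compound 4 (within the scatter), and its estimated value is 89%, between 78% and 100%.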

Compound 4, a percentage reported as activity, at one concentration (the size of the read-out at that concentration, not a potency): 95%
Estimate against measurement, compound 4: 6 percentage points below; low and high end bracket the measured number.
By their numbers in this assay, from the lowest: compounds 1, 2, 4 and 3 (each within the scatter of the next, the first and the last beyond it).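

Going by these compounds alone, the step of a number 3 percentage points higher from compound 2 to compound 4 (within the scatter) is the first measured change at this carbon, and it shows that in this assay taking away this methoxy group leaves the number inside the scatter. The step of a number 10 percentage points higher from compound 1 to compound 4 (within the scatter) shows the same for methoxy in place of hydrogen on an aromatic carbon, so neither change separates compound 4 from its neighbours. No evidence on hand offers a reason for this result. Going by these compounds, whether a hydroxy group, an amine or a chlorine atom at this carbon would move the number beyond the scatter remains open.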